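Acetyl to dimethylamino on the pendant phenyl ring

The source may report more compounds than this note shows. Statements on the series, on what has been measured and on what is new or still open speak of the compounds shown alone.

Measured so far:
compound 1 `COc1cc(C)cc(-c2c(-c3ccnc(-c4ccc(C(C)=O)cc4)c3)cnn2CC#N)c1` — 70%
compound 2 `Cc1cc(O)cc(-c2nn(CC#N)cc2-c2ccnc(-c3ccc(N(C)C)cc3)c2)c1` — -11%

In a functional assay on NCI-H322M cells (Homo sapiens) for cytotoxicity, read by sulforhodamine B assay, with a stated time of 48 h, tested at 10 uM (on this read-out higher numbers stand for a weaker effect at the one concentration tested and lower numbers for a stronger effect), compound 1 gives 70%, the highest of the two numbers; compound 2, the nearest, gives -11%, a gap beyond the scatter. Among the measured compounds shown here, compound 2 differs from compound 1 in more than one place, so its two values say only that the pair sits far apart on this read-out. Compound 3 `COc1cc(C)cc(-c2c(-c3ccnc(-c4ccc(N(C)C)cc4)c3)cnn2CC#N)c1` is not yet measured. It differs from compound 1 in one place: dimethylamino in place of acetyl on an aromatic carbon. For the measured compounds named here, no step between measured compounds covers this change. Since compound 2, which also carries dimethylamino, gives -11%, the step is expected to run downward, toward a stronger effect, and beyond the scatter. Compound 3 is expected to fall to about 15%, with a likely range of -20% to 55%, a step estimated at a number 55 percentage points lower from compound 1 to compound 3 (beyond the scatter).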

Compound 3, a percentage reported as activity, at one concentration (the size of the read-out at that concentration, not a potency): 21%
Beside the measured number, compound 3's estimate is 6 percentage points below it; the range from low to high includes it.
By their numbers in this assay, from the lowest: compound 2; then compound 3; then compound 1.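

With the rest of the molecule unchanged, going from 4-acetylphenyl to 4-(dimethylamino)phenyl gives in this assay a number 49 percentage points lower from compound 1 to compound 3 (beyond the scatter), so a single change at this place on the aromatic ring is enough to shift the read-out, which the earlier pair, differing in more than one place, could not show. The two groups have the same counts of heavy atoms, hydrogen-bond donors and hydrogen-bond acceptors, and neither has a ring or a net charge, so these counts do not separate them; they differ in carbonyl oxygen against amine nitrogen and in the double bond outside aromatic rings. No measurement shown here accounts for the step.

As far as these compounds go, whether a primary amine or a carboxylic acid at this place would read like dimethylamino or like acetyl remains open. Also open, from the compounds shown here alone, is whether the same exchange would give a similar step on the core of compound 2.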